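This account rests on a few compounds, and the source may have more. Where it says the series, first, only, none or still open, it means among the compounds named here.

Three compounds sharing one core were tested in a functional assay on MKN-45 cells (Homo sapiens) for cytotoxicity (a higher number here means a weaker inhibitor, a lower number a stronger inhibitor), and they differ only in the group on a carbonyl carbon. Compound 1 (`COc1ccc(S(=O)(=O)N2CCc3cccc(NC(=O)c4cccs4)c32)cc1`), with thiophen-2-yl there, gives 31 nM. Compound 2 (`COc1ccc(S(=O)(=O)N2CCc3cccc(NC(C)=O)c32)cc1`), with methyl, gives 61 nM, and the gap between the two is a 2.0-fold higher number from compound 1 to compound 2 (0.29 log units; within the scatter). Compound 3 (`COc1ccc(S(=O)(=O)N2CCc3cccc(NC(=O)c4ccccc4)c32)cc1`), with phenyl, gives 250 nM, the highest number of the three and so the weakest inhibitor in this set.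

Compound 4 (`COc1ccc(S(=O)(=O)N2CCc3cccc(NS(=O)(=O)c4ccccc4)c32)cc1`) has phenylsulfonyl in place of benzoyl on a nitrogen on an aromatic ring. Going by the values given here, all the measured steps alter the group on the carbonyl carbon and keep the carbonyl itself, so none of them tests this change directly. The nearest guide to scale is the pair of modest steps into compound 3, an 8.1-fold higher number from compound 1 to compound 3 (0.91 log units; beyond the scatter) and a 4.1-fold higher number from compound 2 to compound 3 (0.61 log units; beyond the scatter). On that basis no firm step beyond the scatter is expected, only a slight lean towards a higher number. The expected step is a 1.6-fold higher number from compound 3 to compound 4 (0.20 log units; within the scatter). For compound 4 the estimated value is 400 nM, with an expected range from 70 nM to 2500 nM.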

Compound 4, half-maximal inhibitory concentration: 562 nM
Compound 4: the middle estimate sits 1.4-fold (0.15 log units) below what was measured; low and high end bracket the measured number.
By their numbers in this assay, from the lowest: compounds 1 and 2 (each within the scatter of the next); then compound 3; then compound 4.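

In this assay, phenylsulfonyl in place of benzoyl on this nitrogen is the first change shown to the carbonyl itself rather than to the group it carries, and with the phenyl ring kept it gives a modest rise beyond the scatter (a 2.2-fold higher number from compound 3 to compound 4 (0.35 log units; beyond the scatter)). Set against the other two groups on this nitrogen, the gap is wider, with a 9.2-fold higher number from compound 2 to compound 4 (0.96 log units; beyond the scatter) for acetyl and an 18-fold higher number from compound 1 to compound 4 (1.26 log units; beyond the scatter) for (thiophen-2-yl)carbonyl, so all three carbonyl-linked groups shown give lower numbers than phenylsulfonyl does, and compound 4 stands as the weakest inhibitor of the four. Nothing available here accounts for this shift.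

Whether the sulfonyl link would leave the same order among its substituents stays open, as phenyl is the only group shown on it, and methylsulfonyl or (thiophen-2-yl)sulfonyl on this nitrogen would separate the effect of the link from that of the group it carries. From the compounds shown here alone, what a urea or a free amine at this nitrogen would give in this assay also remains open.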